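Chloro to methyl at the chain end: compound 3 to compound 4

A few compounds are considered here, and "the series" means these few. Any claim that something is new, unique, unknown or untested is made for them only; others in the source may bear on it.

Measured so far:
- compound 1 `O=C1O[C@H]([C@@H](O)Cn2cc(CNS(=O)(=O)c3ccc(Cl)cc3F)nn2)C(OCc2ccccc2)=C1OCc1ccccc1`: 3390 nM
- compound 2 `Cc1ccc(-c2cn(C[C@H](O)[C@H]3OC(=O)C(OCc4ccccc4)=C3OCc3ccccc3)nn2)cc1`: only a limit, > 100000 nM
- compound 3 `O=C1O[C@H]([C@@H](O)Cn2cc(CCCCl)nn2)C(OCc2ccccc2)=C1OCc1ccccc1`: 24500 nM

In a functional assay on MCF7 cells (Homo sapiens) for antiproliferative activity, read by MTT assay, with a stated time of 72 h (a higher number here means a weaker inhibitor, a lower number a stronger inhibitor), compound 1 gives 3390 nM. For compound 2 the assay reports a limit, > 100000 nM, and no number (the limit of > 100000 nM in this assay, at which 1 of the 3 values shown sits). Compound 3 gives 24500 nM, the highest of the two numbers; its nearest neighbour is compound 1, with a 7.2-fold higher number from compound 1 to compound 3 (0.86 log units; beyond the scatter). Against compound 2 the step is an at least 4.0-fold lower number from compound 2 to compound 3 (0.61 log units; beyond the scatter), so compound 3 sits between the two in this small set.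

The next compound, compound 4 `CCCCc1cn(C[C@H](O)[C@H]2OC(=O)C(OCc3ccccc3)=C2OCc2ccccc2)nn1`, differs from compound 3 by methyl in place of chloro on a saturated chain carbon, three bonds along the chain from an aromatic carbon. Neither measured step isolates the chain terminus: the step from compound 1 to compound 3 removes the sulfonyl-amino group, and the step from compound 2 to compound 3 swaps an aryl group for the chain. Both are modest or larger, but both alter far more than a single terminal atom. Among the compounds with values here, no step bears directly on chloro against methyl, so no change beyond the scatter is expected in this assay, with the small residual risk lying toward a higher number.

Compound 4 is therefore expected to give about 30000 nM, within 12000 nM to 80000 nM. The expected step is a 1.2-fold higher number from compound 3 to compound 4 (0.09 log units; within the scatter).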

Compound 4, half-maximal inhibitory concentration: 7910 nM
Beside the measured number, compound 4's estimate is 3.8-fold (0.58 log units) above it; the measured number lies below the stated range.
By their numbers in this assay, from the lowest: compound 1; then compound 4; then compound 3. At a limit, above all of these: compound 2.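

In this assay, within the data shown here, the chain end is not a silent position: methyl in place of chloro, on a saturated chain carbon, three bonds along the chain from an aromatic carbon, gives a 3.1-fold lower number from compound 3 to compound 4 (0.49 log units; beyond the scatter), the first step that isolates this single terminal atom. The plain butyl chain also stands closer to the sulfonyl-bearing side chain than the chlorinated chain did: propyl in place of ((4-chloro-2-fluorophenyl)sulfonyl)amino gives a 2.3-fold higher number from compound 1 to compound 4 (0.37 log units; beyond the scatter), so compound 1 keeps the lower number, but by a smaller margin than it held over compound 3. Butyl in place of 4-methylphenyl on an aromatic carbon gives an at least 12-fold lower number from compound 2 to compound 4 (1.10 log units; beyond the scatter), a step that rests on a limit for compound 2: the limit of > 100000 nM in this assay, at which 1 of the 4 values shown sits.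

The chloro and methyl pair is a single comparison at this position, so it gives no trend and no cause for the step. As far as these compounds go, whether a terminal amine, a carboxylic acid or a longer chain such as hexyl would bring the number lower still, or reach the level of compound 1, remains open.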